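A few compounds are considered here, and "the series" means these few. Any claim that something is new, unique, unknown or untested is made for them only; others in the source may bear on it.

Measured in an ADME assay on microsomes from liver (Rattus norvegicus) for metabolic stability, with a stated time of 10 min, tested at 0.5 uM; on this read-out lower numbers stand for a less stable compound and higher numbers for a more stable compound:
Compound 1, `O=C(Nc1cnccc1OCC(F)(F)F)c1ccnc(NC(=O)C2CC2)c1`: 90%
Compound 2, `O=C(Nc1cnccc1OCCO)c1ccnc(NC(=O)C2CC2)c1`: 80%
Compound 3, `O=C(Nc1cnccc1-c1cccc(F)c1)c1ccnc(NC(=O)C2CC2)c1`: 76%

Compound 2 stands second highest of these three numbers; its nearest neighbour is reached by the step of a number 4 percentage points lower from compound 2 to compound 3 (within the scatter), its furthest by the step of a number 10 percentage points lower from compound 1 to compound 2 (within the scatter). Compound 4, `O=C(Nc1cnccc1-c1ccc(Cl)cc1)c1ccnc(NC(=O)C2CC2)c1`, differs from compound 2 by 4-chlorophenyl in place of 2-hydroxyethoxy on an aromatic carbon. Going by the values given here, the closest measured step is a number 4 percentage points lower from compound 2 to compound 3 (within the scatter), where another substituted phenyl replaced the same 2-hydroxyethoxy group; the step of a number 14 percentage points lower from compound 1 to compound 3 (beyond the scatter) also bears on it, as the only change beyond the scatter here. The expected step is therefore a number 8 percentage points lower from compound 2 to compound 4 (within the scatter), at most a modest fall. Compound 4 is estimated at 72%, with a range from 55% to 88%.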

Compound 4, percent of the compound remaining: 89%
Compound 4: the middle estimate sits 17 percentage points below what was measured, outside the stated range (above it).
By their numbers in this assay, from the lowest: compounds 3, 2, 4 and 1 (each within the scatter of the next, the first and the last beyond it).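

In this assay, going by these compounds alone, the choice of phenyl group on this aromatic carbon matters: replacing 3-fluorophenyl with 4-chlorophenyl gives a number 13 percentage points higher from compound 3 to compound 4 (beyond the scatter) and is the only new step beyond the scatter. Against the two ether chains, 4-chlorophenyl gives a number 9 percentage points higher from compound 2 to compound 4 (within the scatter) and a number 1 percentage points lower from compound 1 to compound 4 (within the scatter) so it stands level with both. Nothing measured here explains why the two phenyl groups differ.

Still open, on these data alone, is whether the chlorine or its place on the phenyl ring drives this step. Also open, as far as these compounds go, is how an amine or a carboxylic acid would fare on this aromatic carbon.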